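A few compounds are considered here, and "the series" means these few. Any claim that something is new, unique, unknown or untested is made for them only; others in the source may bear on it.

Series of four compounds, three of them measured in a functional assay on the whole organism (strain Wistar) for inhibition, with Rattus norvegicus as the target, read by paw edema, with stated times of 1 h and 3 h, at a dose of 200 mg/kg by the oral route; on this read-out lower numbers stand for less inhibition and higher numbers for more inhibition at the one dose given (going by the name of the read-out). Compound 1 `Cc1ccc(N(C)CC2CCC/C(=C\c3ccc(S(C)(=O)=O)cc3)C2=O)cc1` gives 31.9% in this assay. Compound 2 `Cc1cccc(N(C)CC2CCC/C(=C\c3ccc(S(C)(=O)=O)cc3)C2=O)c1` carries the change (3-methylphenyl in place of 4-methylphenyl on an amine nitrogen); in this assay compound 2 gives 36.2%, and the step of a number 4.3 percentage points higher from compound 1 to compound 2 (within the scatter) is a small one. Compound 3 `COc1ccc(C2(O)/C(=C/c3ccc(C)cc3)CCCC2CN(C)c2ccc(C)cc2)cc1` is built on a different core; the difference between the core of compound 1 and the core of compound 3 is not broken down here. In this assay compound 3 gives 29.8%, a number within the scatter of both compound 1 and compound 2, so no ordering among the three can be read from these values.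

Compound 4 `COc1ccc(C2(O)/C(=C/c3ccc(C)cc3)CCCC2CN(C)c2cccc(C)c2)cc1` has not yet been measured. It differs from compound 3 by 3-methylphenyl in place of 4-methylphenyl on an amine nitrogen, the same change that separates compound 1 from compound 2, at the same kind of place, an amine nitrogen whose other neighbours are saturated chain carbon and saturated chain carbon. Among the compounds with values here, only one earlier instance of this change is available, and it sits on another core. The expected step from compound 3 to compound 4 is about a number 4.2 percentage points higher from compound 3 to compound 4 (within the scatter), resting on the earlier step of a number 4.3 percentage points higher from compound 1 to compound 2 (within the scatter) lying within the scatter. Compound 4 is therefore expected to give about 34% in this assay, with a likely range from 22% to 46%. Whether the change behaves alike on the core of compound 3 is not shown by any measured compound, so the range is kept wide.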

Compound 4, a percentage reported as inhibition, in the whole organism at one dose (the size of the read-out at that dose, not a potency): 29.8%
Estimate against measurement, compound 4: 4.2 percentage points above; measured number inside the range.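

On the core of compound 3, 3-methylphenyl in place of 4-methylphenyl on an amine nitrogen gives, in this assay, no change at the digits printed from compound 3 to compound 4 (within the scatter). Set beside the earlier instance on the other core, the two steps cannot be told apart: the same change on two cores in this assay, a number 4.3 percentage points higher (within the scatter) from compound 1 to compound 2 and no change at the digits printed (within the scatter) from compound 3 to compound 4, 4.3 percentage points apart, within the scatter of two such steps This shows that the change produces no step beyond the scatter on either of these two cores, but it does not show that the change has the same effect on both, since steps this small could hide a real difference, and two pairs at a single dose give no rule for any further core in the series.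

The compounds shown leave open whether anything other than a methylphenyl on this amine nitrogen, such as a longer chain or a group carrying a carboxylic acid, would give a step beyond the scatter on either core. With a single dose and only these closely spaced numbers, they also leave open whether the two cores differ in potency, which a read-out at one dose cannot settle.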